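Compound 3 to compound 4: a thiophen-2-yl swap

The source may report more compounds than this note shows. Statements on the series, on what has been measured and on what is new or still open speak of the compounds shown alone.

Compound 1 (`CCCCCCCCc1ccc(OCC(=O)Cn2nnc(SC)n2)cc1`) gives < 5% in an ADME assay on S9 fraction from liver (Rattus norvegicus) for metabolic stability, read by LC-MS, using NADPH, with a stated time of 30 min (a lower number here means that less of the compound is left, a higher number that more of the compound is left), which is a limit of the assay and not a number. In this assay, compound 2 (`CCCCCCCCc1ccc(OCC(=O)Cn2nnc(-c3cccc(Cl)c3)n2)cc1`) gives 69% and compound 3 (`CCCCCCCCc1ccc(OCC(=O)Cn2nnc(-c3ccc(S(=O)(=O)N(C)C)cc3)n2)cc1`) gives 65%. These two numbers stand together, with a number 4 percentage points lower from compound 2 to compound 3 (within the scatter).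

Compound 4 (`CCCCCCCCc1ccc(OCC(=O)Cn2nnc(-c3cccs3)n2)cc1`) carries thiophen-2-yl in place of 4-(dimethylsulfamoyl)phenyl on an aromatic carbon.

The measured steps at this same place are a number at least 64 percentage points higher from compound 1 to compound 2 (beyond the scatter) and a number at least 60 percentage points higher from compound 1 to compound 3 (beyond the scatter). Both start from the limit of < 5% in this assay, at which 1 of the 3 values shown sits. The expectation rests on compound 2 at 69% and compound 3 at 65%, which both carry a six-membered aromatic ring of carbon only at this place. No five-membered aromatic ring with 1 hetero atom has been measured there, so the range stays wide and leans lower. The expected result is a number 10 percentage points lower from compound 3 to compound 4 (within the scatter), with little or no change beyond the scatter. The estimated value for compound 4 is 55%, with an expected range of 25% to 78%.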

Compound 4, percent of the compound remaining: 8%
For compound 4 the middle estimate is 47 percentage points above the measured one, outside the stated range (below it).
By their numbers in this assay, from the lowest: compound 4; then compounds 3 and 2 (each within the scatter of the next). At a limit, below all of these: compound 1.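

In this assay, this position on the five-membered aromatic ring with 4 nitrogen tells aromatic groups apart, not just aromatic groups from methylsulfanyl: thiophen-2-yl gives a large loss against both six-membered aromatic rings of carbon only (a number 57 percentage points lower from compound 3 to compound 4 (beyond the scatter); a number 61 percentage points lower from compound 2 to compound 4 (beyond the scatter)). An aromatic ring at this place is therefore not enough on its own, as thiophen-2-yl stays close to methylsulfanyl (a number at least 3 percentage points higher from compound 1 to compound 4 (that floor lies within the scatter)). The value of compound 1 is a limit of the assay and not a number: (the limit of < 5% in this assay, at which 1 of the 4 values shown sits).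

The compounds shown do not separate the size of the ring from the sulfur in it, so the outcome with an unsubstituted phenyl or a furan-2-yl at this place remains open. Also open, going by these compounds, is which part of compound 4 is lost in this assay, whether at thiophen-2-yl or elsewhere on the shared core.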